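Acylating the Amino Group of Compound 2

The compounds below may be only part of what the source reports. "The series", "measured", "known", "first", "only" and "open" are said of these compounds alone.

For the measured compounds named here, compound 2 `COc1ccc(-c2csc3nc(-c4cccc(N)c4)cn23)cc1` gives 6100 nM in a functional assay on CCRF-CEM cells (Homo sapiens) for inhibition, read by cell counting, with a stated time of 3 days (a higher number here means a weaker inhibitor, a lower number a stronger inhibitor), the lowest of the two numbers measured so far; compound 1 `Nc1cccc(-c2cn3c(-c4ccc(Cl)cc4)csc3n2)c1` gives 21000 nM, and a 3.4-fold lower number from compound 1 to compound 2 (0.54 log units; beyond the scatter) separates them. Compound 3 `C=C(Br)C(=O)Nc1cccc(-c2cn3c(-c4ccc(OC)cc4)csc3n2)c1` carries (1-bromoethenyl)carbonyl in place of hydrogen on a nitrogen on an aromatic ring. Going by the values given here, the one measured step swapped a chloro for a methoxy on a ring and says nothing about a group entering on the nitrogen, so no measured step bears directly on this change. With nothing to lean on, the estimate for compound 3 is 3000 nM, within a range from 500 nM to 15000 nM. This corresponds to an expected step of a 2.0-fold lower number from compound 2 to compound 3 (0.31 log units; beyond the scatter).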

Compound 3, half-maximal inhibitory concentration: 500 nM
Estimate against measurement, compound 3: 6.0-fold (0.78 log units) above; the range from low to high includes it.
By their numbers in this assay, from the lowest: compound 3; then compound 2; then compound 1.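

The nitrogen on the aromatic ring tolerates substitution, and the free amino group of compound 2 is not needed for activity: with (1-bromoethenyl)carbonyl on this nitrogen, the result is a 12-fold lower number from compound 2 to compound 3 (1.09 log units; beyond the scatter). This single change at the nitrogen is a large step, and it replaces a hydrogen with 5 heavy atoms. Nothing shown gives a reason for the gain.

On these data alone, it remains open whether the gain needs the bromine or the double bond, or comes with the carbonyl alone, as a plain acetyl or an unbrominated propenoyl group on the same nitrogen would show. As far as these compounds go, it is also open whether the same group would lower the number on compound 1.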